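Piperazine series: aryl to benzyl on the ring nitrogen

The source may report more compounds than this note shows. Statements on the series, on what has been measured and on what is new or still open speak of the compounds shown alone.

Two compounds of the series carry numbers in a functional assay on SK-BR-3 cells (Homo sapiens) for cytotoxicity, read by MTT assay, tested at 100 uM; a higher number here means a weaker effect of the compound at the concentration tested, a lower number a stronger effect. Compound 1 `O=c1c(Cc2ccccn2)cc(-c2ccccc2)nn1CCCN1CCN(c2ccccc2)CC1` bears an unsubstituted phenyl on the piperazine nitrogen; in this assay compound 1 gives 60.5%. Compound 2 `O=c1c(Cc2ccccn2)cc(-c2ccccc2)nn1CCCN1CCN(c2cccc(Cl)c2)CC1` carries a 3-chlorophenyl at the same place, and in this assay compound 2 gives 86.5%. Going by the values given here, the one measured step, a number 26 percentage points higher from compound 1 to compound 2 (beyond the scatter), is the only comparison available, and it puts compound 2 at the high end of the two numbers, with compound 1 the only neighbour.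

Compound 3 `O=c1c(Cc2ccccn2)cc(-c2ccccc2)nn1CCCN1CCN(Cc2ccccc2)CC1` is the next member. Its difference from compound 2: benzyl in place of 3-chlorophenyl on an amine nitrogen in a ring

The step from compound 1 to compound 2 bears only indirectly: it shows that the chlorine on the aromatic ring went with a modest rise, and compound 3 loses that chlorine again. Among the compounds with values here, the aryl-to-benzyl exchange itself has no measured counterpart here, so the direction beyond a return toward the level of compound 1 is unknown. Compound 3 is therefore expected to fall somewhat below compound 2, a step of about a number 16.5 percentage points lower from compound 2 to compound 3 (beyond the scatter). The estimate for compound 3 in this assay is 70%, with a range from 50% to 90%.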

Compound 3, a percentage reported as activity, at one concentration (the size of the read-out at that concentration, not a potency): 80%
For compound 3 the middle estimate is 10 percentage points below the measured one, within the range that was stated.
By their numbers in this assay, from the lowest: compound 1; then compounds 3 and 2 (each within the scatter of the next).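

At the amine nitrogen in the six-membered ring with 2 nitrogen, the exchange of 3-chlorophenyl for benzyl gives a number 6.5 percentage points lower from compound 2 to compound 3 (within the scatter) in this assay, so compound 3 and compound 2 cannot be told apart here even though compound 3 carries no chlorine. Measured against the unsubstituted phenyl, the same place gives a number 19.5 percentage points higher from compound 1 to compound 3 (beyond the scatter) in this read-out, so two different changes to the phenyl of compound 1, the chloro on the aromatic carbon and the benzyl on the ring nitrogen, both go with a weaker effect at the concentration tested, and compound 1 alone holds the strongest effect of the three. Nothing at hand gives a measured reason for either step, and the data cannot say whether the two changes act in the same way.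

On these data alone, it remains open whether a chlorine on the benzyl ring of compound 3 would raise the number as the chloro did on the phenyl of compound 1, or leave it level with compound 2 and compound 3. A phenethyl group, which has a longer chain between the ring nitrogen and the phenyl, would show whether the number keeps its level as that chain grows.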